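Replacing an Oxetane Amide with a Methoxypyrrolidine Amide

The source may hold more compounds than are shown below. What is called first, only, known or untested is meant among the compounds shown, and "the series" means these compounds.

Measured compounds:
compound 1 `O=C([C@@H]1CCCN(S(=O)(=O)c2ccc(S(=O)(=O)C3COC3)cc2)C1)N1CCC(F)(F)CC1`: 361 nM
compound 2 `CCN(CC)S(=O)(=O)c1ccc(S(=O)(=O)N2CCC[C@@H](C(=O)NC3COC3)C2)cc1`: 13800 nM

In a functional assay on BXPC-3 cells (Homo sapiens) for inhibition, read by MTT assay, with a stated time of 7 days (on this read-out higher numbers stand for weaker inhibition and lower numbers for stronger inhibition), compound 2 gives 13800 nM, the highest number of the two measured, meaning the weaker inhibition. Compound 1, which differs from it in several places at once, gives 361 nM, a far lower number that lies well beyond the usual scatter. Compound 3 `CCN(CC)S(=O)(=O)c1ccc(S(=O)(=O)N2CCC[C@@H](C(=O)N3CC[C@H](OC)C3)C2)cc1` keeps the whole of compound 2 except one change on the carbonyl carbon: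

3-methoxypyrrolidin-1-yl in place of (oxetan-3-yl)amino on a carbonyl carbon

The entering group carries no hydrogen-bond donor, while the leaving one had one. For the measured compounds named here, no measured pair isolates this exact change, so the direction is uncertain, but compound 1 shows that much stronger inhibition is possible. A modest gain is expected, with the step from compound 2 to compound 3 estimated at a 3.5-fold lower number from compound 2 to compound 3 (0.54 log units; beyond the scatter). Compound 3 is expected to give about 4000 nM in this assay, within a range of 900 nM to 15000 nM.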

Compound 3, half-maximal inhibitory concentration: 6750 nM
Compound 3: the middle estimate sits 1.7-fold (0.23 log units) below what was measured; the range from low to high includes it.
By their numbers in this assay, from the lowest: compound 1; then compound 3; then compound 2.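

Placing 3-methoxypyrrolidin-1-yl in place of (oxetan-3-yl)amino on the carbonyl carbon gives a 2.0-fold lower number from compound 2 to compound 3 (0.31 log units; beyond the scatter) in this assay and, though modest, this step lies beyond the usual scatter. For the compounds shown here, it is the first reading of a change at this one position, with the rest of compound 2 kept intact. It shows that the amide hydrogen of compound 2 is not required for the inhibition seen here, and that the larger group, which brings a defined stereocentre, is accepted at this position. No measured evidence bears on the reason for the step.

Open, on these data alone, is whether the methoxy group or the pyrrolidine ring accounts for the gain, as both enter together. An unsubstituted pyrrolidine or a morpholine on the same carbonyl carbon would help to separate the two.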